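The compounds below may be only part of what the source reports. "The series", "measured", "known", "first", "only" and "open" are said of these compounds alone.

Three compounds share one core and differ only in the group carried on one aromatic carbon. Compound 1 `CC1C(=O)N(c2ccccc2C(=O)OCC2CCCN(CCCc3ccccc3)C2)C(=O)C1C` gives 6000 nM in a functional assay with Neuronal acetylcholine receptor; alpha3/beta4 (Homo sapiens) as the target; a lower number here means a stronger inhibitor, a higher number a weaker inhibitor. Compound 2 `CC(C)C1CC(=O)N(c2ccccc2C(=O)OCC2CCCN(CCCc3ccccc3)C2)C1=O` gives 2500 nM in the same assay, and compound 3 `O=C(OCC1CCCN(CCCc2ccccc2)C1)c1ccccc1C(F)(F)F` gives 3200 nM. Among these three numbers compound 3 stands second highest; its nearest neighbour is compound 2, within the scatter, and even the furthest, compound 1, lies within the scatter of it.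

The measured steps all concern that same position. The step of a 2.4-fold lower number from compound 1 to compound 2 (0.38 log units; beyond the scatter) is modest but beyond the scatter. The steps of a 1.9-fold lower number from compound 1 to compound 3 (0.27 log units; within the scatter) and a 1.3-fold higher number from compound 2 to compound 3 (0.11 log units; within the scatter) stay within the scatter, so exchanging a ring for trifluoromethyl at this position has hardly moved the number.

Compound 4 `O=C(OCC1CCCN(CCCc2ccccc2)C1)c1ccccc1-c1ccccc1` carries the change (phenyl in place of trifluoromethyl on an aromatic carbon). Since every change at this carbon so far has given at most a modest step, and the exchange of a ring-bearing group for a small group gave steps like a 1.9-fold lower number from compound 1 to compound 3 (0.27 log units; within the scatter) and a 1.3-fold higher number from compound 2 to compound 3 (0.11 log units; within the scatter), no step beyond the scatter is expected. Compound 4 is therefore estimated at 3000 nM in this assay, with a range from 1200 nM to 8000 nM, a step of a 1.1-fold lower number from compound 3 to compound 4 (0.03 log units; within the scatter) that is expected to sit within the scatter.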

Compound 4, half-maximal inhibitory concentration: 1700 nM
Compound 4: the middle estimate sits 1.8-fold (0.25 log units) above what was measured; measured number inside the range.
By their numbers in this assay, from the lowest: compounds 4, 2, 3 and 1 (each within the scatter of the next, the first and the last beyond it).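

Phenyl puts a six-membered aromatic ring of carbon only on this aromatic carbon, ortho to a large group, yet in this assay the steps stay within the scatter: a 1.9-fold lower number from compound 3 to compound 4 (0.27 log units; within the scatter) and a 1.5-fold lower number from compound 2 to compound 4 (0.17 log units; within the scatter). Within the data shown here, a carbon-only aromatic ring therefore fits the same narrow band as trifluoromethyl and the five-membered non-aromatic ring of compound 2, a wider range of groups at this position than the earlier compounds covered. Only the comparison with the dimethyl-substituted ring of compound 1 passes beyond the scatter, with a 3.5-fold lower number from compound 1 to compound 4 (0.55 log units; beyond the scatter), the largest step among these compounds but still a modest one, and no measurement is available that would account for any of these steps.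

The compounds shown leave open whether an amine, a carboxylic acid or a longer chain on this aromatic carbon would produce more than a modest step. They also leave open how the number would respond to a substituted phenyl here, such as one carrying a methoxy group, or to a change elsewhere in the shared core.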